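Chloro to trifluoromethyl swap on the aryl group

The source may hold more compounds than are shown below. What is called first, only, known or untested is meant among the compounds shown, and "the series" means these compounds.

Measured in a functional assay on PC-12 cells (Rattus norvegicus) for cytotoxicity, read by MTT assay, with stated times of 2 h and 24 h, tested at 1 uM; on this read-out higher numbers stand for a stronger effect at the one concentration tested and lower numbers for a weaker effect:
compound 1, `Oc1cc(C(F)(F)F)ccc1-c1nc(-c2ccccc2O)n(-c2ccccc2Cl)n1`, gives 70.1%
compound 2, `Oc1cc(C(F)(F)F)ccc1-c1nc(-c2ccccc2O)n(-c2ccccc2C(F)(F)F)n1`, gives 71%
compound 3, `Oc1cc(C(F)(F)F)ccc1-c1nc(-c2ccccc2O)n(-c2cccc(Cl)c2)n1`, gives 72.3%

Compound 2 differs from compound 1 by trifluoromethyl in place of chloro on an aromatic carbon; in this assay this made a step of a number 0.9 percentage points higher from compound 1 to compound 2 (within the scatter). Compound 3 differs from compound 1 by 3-chlorophenyl in place of 2-chlorophenyl on an aromatic nitrogen, the two cores holding the same atoms joined differently; the step is a number 2.2 percentage points higher from compound 1 to compound 3 (within the scatter). Between compound 2 and compound 3 the step is a number 1.3 percentage points higher from compound 2 to compound 3 (within the scatter). All three numbers lie within the scatter of one another, so no order among them is claimed.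

Compound 4, `Oc1cc(C(F)(F)F)ccc1-c1nc(-c2ccccc2O)n(-c2cccc(C(F)(F)F)c2)n1`, is not yet measured. It differs from compound 3 by trifluoromethyl in place of chloro on an aromatic carbon. This is the same kind of change as from compound 1 to compound 2, but not the same: there the group sits ortho to a large group, here meta to a large group.

The step from compound 3 to compound 4 in this assay is expected to be about a number 0.3 percentage points lower from compound 3 to compound 4 (within the scatter), because the earlier step of the same kind, a number 0.9 percentage points higher from compound 1 to compound 2 (within the scatter), stayed within the scatter, and the three measured numbers sit close together. Compound 4 is estimated at 72%, with a range from 63% to 81%.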

Compound 4, a percentage reported as activity, at one concentration (the size of the read-out at that concentration, not a potency): 71.5%
Compound 4: the middle estimate sits 0.5 percentage points above what was measured; measured number inside the range.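

In this assay, trifluoromethyl in place of chloro on the core of compound 3 gives a number 0.8 percentage points lower from compound 3 to compound 4 (within the scatter), while the two other new steps, a number 0.5 percentage points higher from compound 2 to compound 4 (within the scatter) and a number 1.4 percentage points higher from compound 1 to compound 4 (within the scatter), also show no separation of compound 4 from compounds 1 and 2. Set beside the earlier case, the same change does not differ measurably between the two cores: the same change on two cores in this assay, a number 0.9 percentage points higher (within the scatter) from compound 1 to compound 2 and a number 0.8 percentage points lower (within the scatter) from compound 3 to compound 4, 1.7 percentage points apart, within the scatter of two such steps. Within the data shown here, the change therefore stays within the scatter on both cores, but this does not show that it is without effect on other cores or at other concentrations, and it gives no direction for the step.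

The compounds shown leave open whether any group other than chloro or trifluoromethyl on the aryl ring would separate from these numbers, for example an amine, a carboxylic acid or a methoxy group. As far as these compounds go, replacing either hydroxy group on the shared core also remains open.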